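From a difluorophenyl to a bromophenyl at the aryl ether

This account rests on a few compounds, and the source may have more. Where it says the series, first, only, none or still open, it means among the compounds named here.

Three compounds share one core and differ in the phenyl group on an oxygen on an aromatic ring, and all three were tested in a functional assay on HepG2 cells (Homo sapiens) for antiproliferative activity, read by MTT assay, with a stated time of 72 h; a higher number here means a weaker inhibitor, a lower number a stronger inhibitor. Compound 1, `Cc1nn(C)c(Oc2ccc(I)cc2)c1/C=N\CCCCCOc1cc2oc(=O)cc(C)c2cc1Cl`, gives > 25000 nM, which is a limit of the assay rather than a number. Compound 2, `Cc1nn(C)c(Oc2ccc(F)cc2F)c1/C=N\CCCCCCOc1cc2oc(=O)cc(C)c2cc1Cl`, gives > 25000 nM, again a limit. Within the data shown here, compound 3, `Cc1nn(C)c(Oc2ccc(F)c(F)c2)c1/C=N\CCCCCCOc1cc2oc(=O)cc(C)c2cc1Cl`, gives > 25000 nM, also a limit, so compound 3 stands where every value so far stands, at the limit of > 25000 nM in this assay, at which 3 of the 3 values shown sit. Among the measured compounds shown here, the only step between measured compounds is a step that the two limits leave unreadable from compound 2 to compound 3, and it cannot be read. Compound 4, `Cc1nn(C)c(Oc2ccc(Br)cc2)c1/C=N\CCCCCCOc1cc2oc(=O)cc(C)c2cc1Cl`, carries 4-bromophenyl in place of 3,4-difluorophenyl on an oxygen on an aromatic ring. With no readable step to lean on, compound 4 is expected to remain at the limit. The expected step is a step that the limit leaves unreadable from compound 3 to compound 4. Compound 4 is estimated at 30000 nM, with a range from 10000 nM to 100000 nM.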

Compound 4, half-maximal inhibitory concentration: 4630 nM
Beside the measured number, compound 4's estimate is 6.5-fold (0.81 log units) above it, outside the stated range (below it).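

The phenyl group on this oxygen does set the result in this assay: 4-bromophenyl brings a real number where both difluorophenyl groups gave none, with an at least 5.3-fold lower number from compound 3 to compound 4 (0.73 log units; beyond the scatter) and an at least 5.3-fold lower number from compound 2 to compound 4 (0.73 log units; beyond the scatter). Among these compounds, only compound 4 has moved off the limit: the limit of > 25000 nM in this assay, at which 3 of the 4 values shown sit.

On these data alone, the full size of both steps stays unknown, since each starts from a limit. As far as these compounds go, whether a 4-chlorophenyl or a 4-methoxyphenyl group on this oxygen would bring a similar number also stays open.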